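Aryl group change from compound 2 to compound 3

The compounds below may be only part of what the source reports. "The series", "measured", "known", "first", "only" and "open" are said of these compounds alone.

Within the data shown here, in a functional assay on MDA-MB-231 cells (Homo sapiens) for cytotoxicity, read by MTT assay, with a stated time of 72 h (on this read-out higher numbers stand for weaker inhibition and lower numbers for stronger inhibition), compound 1 (`Cc1ccc(F)cc1NC(=O)CN1CCN(c2nnc(Cc3ccccc3)c3ccccc23)CC1`) gives 19200 nM and compound 2 (`Cc1cccc(Cl)c1NC(=O)CN1CCN(c2nnc(Cc3ccccc3)c3ccccc23)CC1`) gives 3920 nM, the lower of the two numbers so far. Compound 3 (`O=C(CN1CCN(c2nnc(Cc3ccccc3)c3ccccc23)CC1)Nc1cc(C(F)(F)F)ccc1Cl`) keeps the shared core and carries 2-chloro-5-(trifluoromethyl)phenyl in place of 2-chloro-6-methylphenyl on an amide-type nitrogen. Among the measured compounds shown here, one measured step bears on this change: a 4.9-fold lower number from compound 1 to compound 2 (0.69 log units; beyond the scatter), which swapped 5-fluoro-2-methylphenyl for 2-chloro-6-methylphenyl at that same place. For the measured compounds named here, it shows that the number can move with this group, but no measured compound carries the trifluoromethyl group, so the guide is indirect. A smaller step than that one is expected, leaning towards a higher number. The expected change is a 1.8-fold higher number from compound 2 to compound 3 (0.25 log units; within the scatter). For compound 3 the estimated value is 7000 nM, with an expected range of 2200 nM to 22000 nM.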

Compound 3, half-maximal inhibitory concentration: 19500 nM
Compound 3: middle estimate off by 2.8-fold (0.44 log units), on the low side; the range from low to high includes it.
By their numbers in this assay, from the lowest: compound 2; then compounds 1 and 3 (each within the scatter of the next).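

In this assay, keeping the 2-chloro part of the aryl group on the amide-type nitrogen does not keep the low number of compound 2 once 2-chloro-5-(trifluoromethyl)phenyl enters: a 5.0-fold higher number from compound 2 to compound 3 (0.70 log units; beyond the scatter). Compound 2 now stands apart from both other compounds by steps beyond the scatter, while the aryl groups of compound 1 and compound 3 read alike despite their different substituents: a 1.0-fold higher number from compound 1 to compound 3 (0.01 log units; within the scatter). No measurement shown here accounts for either step.

It remains open whether the step to compound 3 follows the departure of the 6-methyl group or the entry of the 5-trifluoromethyl group, as the compounds shown do not separate the two. Also open, on these data alone, is how a 2,6-dichlorophenyl group, or an aryl group carrying an amine or a carboxylic acid, would read at this place.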